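Extending the ether chain toward a terminal ketone

This account rests on a few compounds, and the source may have more. Where it says the series, first, only, none or still open, it means among the compounds named here.

Compound 1, `C=CCc1cc(C(C)=O)c(O)cc1OCCCC#N`: 47%
Compound 2, `C=CCc1cc(C(C)=O)c(O)cc1OCCCCCCCC#N`: 88%
Compound 3, `C=CCc1cc(C(C)=O)c(O)cc1OCCCCO`: 48%

Of the compounds shown here, three sharing one core have been tested in an assay on isolated protein for inhibition of leukotriene B4 receptor 1 (Homo sapiens), tested at 10 uM; a higher number here means more inhibition at the concentration tested (going by the name of the read-out), a lower number less inhibition. Compound 3 stands second highest of the three numbers; its nearest neighbour is compound 1 (a number 1 percentage points higher from compound 1 to compound 3 (within the scatter)), and its furthest is compound 2 (a number 40 percentage points lower from compound 2 to compound 3 (beyond the scatter)).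

Compound 4, `C=CCc1cc(C(C)=O)c(O)cc1OCCCCCC(C)=O`, is not yet measured. Its change from compound 3 is 2-oxopropyl in place of hydroxy on a saturated chain carbon, four bonds along the chain from an oxygen on an aromatic ring. The step that bears most on it is the lengthening of the chain from compound 1 to compound 2, where the terminal nitrile was kept: a number 41 percentage points higher from compound 1 to compound 2 (beyond the scatter). The step from compound 1 to compound 3, exchanging nitrile for hydroxymethyl at a fixed chain length, was small: a number 1 percentage points higher from compound 1 to compound 3 (within the scatter). So in this assay the chain length has mattered far more than the identity of the terminal group, and compound 4 carries a longer chain ending in a carbonyl acceptor, though shorter than that of compound 2. The expected step is therefore an increase, a number 22 percentage points higher from compound 3 to compound 4 (beyond the scatter), beyond the scatter but short of the full step to compound 2. The estimate for compound 4 is 70%, expected to fall between 50% and 88%.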

Compound 4, a percentage reported as inhibition, at one concentration (the size of the read-out at that concentration, not a potency): 98%
For compound 4 the middle estimate is 28 percentage points below the measured one; measured number above the stated range.
By their numbers in this assay, from the lowest: compounds 1 and 3 (each within the scatter of the next); then compounds 2 and 4 (each within the scatter of the next).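

The 2-oxopropyl group in place of hydroxy, on a saturated chain carbon four bonds along the chain from an oxygen on an aromatic ring, brings a large change in this assay (a number 50 percentage points higher from compound 3 to compound 4 (beyond the scatter)), and the exchange of cyano for 2-acetylethyl is of similar size (a number 51 percentage points higher from compound 1 to compound 4 (beyond the scatter)). Within the data shown here, until now, the only high number belonged to a compound ending in a nitrile, so the high level could have been tied to that end group; it now appears with a chain ending in a ketone as well. Compound 4 also cannot be separated from compound 2 (a number 10 percentage points higher from compound 2 to compound 4 (within the scatter)), even though its chain is the shorter of the two, so among these four compounds a longer chain goes with the high numbers, whichever of these two end groups it carries, and no listed compound goes against that.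

As far as these compounds go, whether a carboxylic acid or an amine at the end of this chain would hold the high number remains open, as does whether a shorter chain ending in acetyl would fall to the level of compounds 1 and 3. Nothing given here accounts for these steps.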